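The source may hold more compounds than are shown below. What is called first, only, known or untested is meant among the compounds shown, and "the series" means these compounds.

The measured compounds in an ADME assay on cells (Mus musculus, strain BALB/c) for cytotoxicity, read by MTT assay, with a stated time of 24 h; on this read-out higher numbers stand for lower toxicity in this test and lower numbers for higher toxicity in this test:

compound 1, `COc1cc(-c2nnc(SCc3cccc(Br)c3)o2)ccc1O`, gives 382000 nM
compound 2, `COc1cc(-c2nnc(SCc3ccc(F)cc3F)o2)ccc1O`, gives 520000 nM
compound 3, `COc1cc(-c2nnc(SCc3ccccc3)o2)ccc1O`, gives 211000 nM

Among the compounds with values here, compound 2 shows the largest of the three numbers, though the step of a 1.4-fold higher number from compound 1 to compound 2 (0.13 log units; within the scatter) is within the scatter, so compound 2 and compound 1 cannot be told apart; only the step of a 2.5-fold lower number from compound 2 to compound 3 (0.39 log units; beyond the scatter) lies beyond the scatter. Compound 4, `COc1cc(-c2nnc(SCc3ccc(F)cc3F)o2)ccc1OCc1ccc(F)cc1F`, has not yet been measured. It differs from compound 2 in one place: 2,4-difluorobenzyl in place of hydrogen on an oxygen on an aromatic ring. Within the data shown here, the three measured steps all alter the aryl group on the saturated chain carbon bound to a sulfur or a bromo on it, as in a 1.8-fold lower number from compound 1 to compound 3 (0.26 log units; within the scatter); none of them touches the oxygen on the aromatic ring, so no measured step bears directly on this change. The measured steps were all small, so the only reasonable expectation is a step of a 1.3-fold lower number from compound 2 to compound 4 (0.11 log units; within the scatter) that is not confidently beyond the scatter, with a wide range. Compound 4 is therefore estimated at 400000 nM, between 130000 nM and 1200000 nM in this assay.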

Compound 4, half-maximal cytotoxic concentration: 182000 nM
Beside the measured number, compound 4's estimate is 2.2-fold (0.34 log units) above it, and the stated range covers the measured number.
By their numbers in this assay, from the lowest: compounds 4, 3, 1 and 2 (each within the scatter of the next, the first and the last beyond it).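

Replacing the hydrogen on this oxygen with 2,4-difluorobenzyl gives a 2.9-fold lower number from compound 2 to compound 4 (0.46 log units; beyond the scatter) in this assay, so the oxygen on the aromatic ring is a place where a change can move this read-out beyond the scatter, here towards higher toxicity in this test. The earlier steps shown here changed only the aryl group on the saturated chain carbon bound to a sulfur, and the only one of them beyond the scatter was a 2.5-fold lower number from compound 2 to compound 3 (0.39 log units; beyond the scatter), so they could say nothing about this oxygen. No evidence at hand accounts for the step. With one group shown on this oxygen, the compounds leave open whether a methyl, an unsubstituted benzyl or a longer chain ending in a carboxylic acid would move the number the same way. They also leave open whether the same 2,4-difluorobenzyl would do so in compound 1 or compound 3.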